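The source may hold more compounds than are shown below. What is called first, only, known or untested is meant among the compounds shown, and "the series" means these compounds.

Within the data shown here, compound 3 `O=C(/C=C/c1cccs1)Nc1ccc2ncnc(Nc3cccc(Cl)c3)c2c1` gives 9.23 ug/mL in a functional assay on A549 cells (Homo sapiens) for antiproliferative activity, read by MTT assay, with a stated time of 48 h (on this read-out higher numbers stand for weaker inhibition and lower numbers for stronger inhibition), the second highest of the three numbers so far: compound 1 `O=C(/C=C/c1ccc(Cl)cc1)Nc1ccc2ncnc(Nc3cccc(Cl)c3)c2c1` gives 12.4 ug/mL and compound 2 `COc1cccc(/C=C/C(=O)Nc2ccc3ncnc(Nc4cccc(Cl)c4)c3c2)c1` gives 2.58 ug/mL. Compound 4 `O=C(/C=C/c1ccc([N+](=O)[O-])cc1)Nc1ccc2ncnc(Nc3cccc(Cl)c3)c2c1` differs from compound 3 by 4-nitrophenyl in place of thiophen-2-yl on a double-bonded chain carbon bound to a double-bonded chain carbon. Among the measured compounds shown here, two measured steps bear on this change. The closer comparison is the exchange of thiophen-2-yl for 4-chlorophenyl, which gave a 1.3-fold lower number from compound 1 to compound 3 (0.13 log units; within the scatter), a step inside the scatter; the exchange for 3-methoxyphenyl gave a 3.6-fold higher number from compound 2 to compound 3 (0.55 log units; beyond the scatter), a modest step. Because a 1.3-fold lower number from compound 1 to compound 3 (0.13 log units; within the scatter) stayed within the scatter, compound 4 is expected to show a 1.1-fold higher number from compound 3 to compound 4 (0.03 log units; within the scatter) in this assay, no shift beyond the scatter. Compound 4 is therefore estimated at 10 ug/mL, within a range from 3.5 ug/mL to 30 ug/mL.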

Compound 4, half-maximal inhibitory concentration: 5.26 ug/mL
Compound 4: the middle estimate sits 1.9-fold (0.28 log units) above what was measured; the range from low to high includes it.
By their numbers in this assay, from the lowest: compound 2; then compounds 4, 3 and 1 (each within the scatter of the next, the first and the last beyond it).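

In this assay the change to 4-nitrophenyl gives a 1.8-fold lower number from compound 3 to compound 4 (0.24 log units; within the scatter), so this place on the double-bonded chain carbon accepts a larger six-membered aromatic ring without a shift beyond the scatter. Exchange on the aromatic carbon itself does register: nitro in place of chloro gives a 2.4-fold lower number from compound 1 to compound 4 (0.37 log units; beyond the scatter), the first direct reading of that exchange. Even so, 3-methoxyphenyl keeps the lowest number, with a 2.0-fold higher number from compound 2 to compound 4 (0.31 log units; beyond the scatter).

Nothing shown gives a reason for these steps. As far as these compounds go, it remains open how an amine or a carboxylic acid on that aromatic carbon would read.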